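A Hydroxypropyl Carbamoyl Added to a Free Hydrazide

The compounds below may be only part of what the source reports. "The series", "measured", "known", "first", "only" and "open" are said of these compounds alone.

Compound 3 `COc1cc(NC(C)CCCNC(=O)NN)c2ncccc2c1` ends in a free hydrazide on the shared core. In a functional assay on SW-620 cells (Homo sapiens) for inhibition, read by MTT assay, with a stated time of 4 days (a higher number here means a weaker inhibitor, a lower number a stronger inhibitor), compound 3 gives only a limit, > 100000 nM, so where it truly stands cannot be said more closely. Compound 1 `COc1cc(NC(C)CCCNC(=O)NNC(=O)N(CCO)CCO)c2ncccc2c1` carries bis(2-hydroxyethyl)carbamoyl on that amine nitrogen. In this assay compound 1 likewise gives only a limit, > 100000 nM. Among the measured compounds shown here, the one single-point step among the measured compounds is therefore a step that the two limits leave unreadable from compound 1 to compound 3, and its size cannot be read because the limit of > 100000 nM in this assay, at which 2 of the 3 values shown sit, caps both ends. For the measured compounds named here, compound 2 `COc1cc(NC(C)CCCNC(=O)NNC(=O)N(C)C(c2ccccc2)c2ccccc2)c2ncccc2c1` is the only compound with a number: in this assay compound 2 gives 27000 nM, a weak inhibition.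

Compound 4 `COc1cc(NC(C)CCCNC(=O)NNC(=O)NCCCO)c2ncccc2c1` differs from compound 3 by (3-hydroxypropyl)carbamoyl in place of hydrogen on an amine nitrogen. Going by the values given here, no measured step gives a number for this kind of change. Compound 1, with its related hydroxyalkyl carbamoyl, sits at the limit. Compound 2 alone reaches a readable number, and only a weak one. The step of a number no higher from compound 3 to compound 4 (the limit leaves the size open) is therefore expected to be small or unreadable, with no direction that can be claimed beyond the scatter. In this assay compound 4 is expected to give 100000 nM, within 30000 nM to 300000 nM, and quite possibly only a limit once more.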

Compound 4, half-maximal inhibitory concentration: > 100000 nM
Compound 4: a limit, no number; the forecaster's own chance of this, stated with the estimate: 65%; the middle value sits exactly at the limit.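

In this assay compound 4 gives > 100000 nM as a limit and not a number. Among the compounds shown here, no step from compound 4 to compound 3 or compound 1 can be read, because each is capped at both ends: the limit of > 100000 nM in this assay, at which 3 of the 4 values shown sit.

The compounds shown leave open how far (3-hydroxypropyl)carbamoyl in place of hydrogen actually moves inhibition on the shared core.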